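This account rests on a few compounds, and the source may have more. Where it says the series, first, only, none or still open, it means among the compounds named here.

Series notes. Three compounds share one core and differ only at the amide end: compound 1 `O=C(/C=C/c1ccc(NC(=O)Nc2ccc(Cl)c(C(F)(F)F)c2)cc1)NC1CCC1`, compound 2 `CC(NC(=O)/C=C/c1ccc(NC(=O)Nc2ccc(Cl)c(C(F)(F)F)c2)cc1)c1ccccc1` and compound 3 `CC1CN(C(=O)/C=C/c2ccc(NC(=O)Nc3ccc(Cl)c(C(F)(F)F)c3)cc2)CC(C)O1`. In a functional assay on MX1 cells (Homo sapiens) for inhibition, read by MTT assay, with a stated time of 120 h (on this read-out higher numbers stand for weaker inhibition and lower numbers for stronger inhibition), compound 1 gives 4530 nM, compound 2 gives 3130 nM and compound 3 gives 12800 nM. Compound 2 holds the lowest number of the three, though its gap to compound 1 stays within the scatter; only compound 3 sits clearly apart. The steps measured so far are a 1.4-fold lower number from compound 1 to compound 2 (0.16 log units; within the scatter), a 2.8-fold higher number from compound 1 to compound 3 (0.45 log units; beyond the scatter) and a 4.1-fold higher number from compound 2 to compound 3 (0.61 log units; beyond the scatter).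

Compound 4 `CC(NC(=O)/C=C/c1ccc(NC(=O)Nc2cc(C(F)(F)F)ccc2Cl)cc1)c1ccccc1` is not yet measured. It keeps the (1-phenylethyl)amide of compound 2 and changes only the urea aryl: 2-chloro-5-(trifluoromethyl)phenyl in place of 4-chloro-3-(trifluoromethyl)phenyl on an amide-type nitrogen. Among the compounds with values here, none of the measured steps touches that aryl; every one of them alters the amide side. So no measured step bears on this change, and the expectation rests on compound 2 alone, with a wide range. Compound 4 is expected in this assay to give about 6500 nM, between 1500 nM and 28000 nM. Within the data shown here, the step expected from compound 2 to compound 4 is a 2.1-fold higher number from compound 2 to compound 4 (0.32 log units; beyond the scatter), a number estimated as somewhat higher, but with no measured step behind it.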

Compound 4, half-maximal inhibitory concentration: 1890 nM
Beside the measured number, compound 4's estimate is 3.4-fold (0.54 log units) above it; the range from low to high includes it.
By their numbers in this assay, from the lowest: compounds 4, 2 and 1 (each within the scatter of the next, the first and the last beyond it); then compound 3.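

The urea aryl on the amide-type nitrogen now has a measured step of its own, as all earlier steps altered the amide side. In this assay, 2-chloro-5-(trifluoromethyl)phenyl in place of 4-chloro-3-(trifluoromethyl)phenyl gives a 1.7-fold lower number from compound 2 to compound 4 (0.22 log units; within the scatter), so rearranging the same atoms on this aryl does not separate the two compounds, at least with the (1-phenylethyl)amide in place. Nothing available explains this outcome.

Going by these compounds, whether 2-chloro-5-(trifluoromethyl)phenyl gives the same result alongside the cyclobutyl amide of compound 1 or the 2,6-dimethylmorpholin-4-yl amide of compound 3 remains open. Also open, on these data alone, is how this position responds to a different aryl substitution, such as a nitrile or methoxy group in place of the chlorine or the trifluoromethyl, or to an unsubstituted phenyl.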